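The source may report more compounds than this note shows. Statements on the series, on what has been measured and on what is new or still open speak of the compounds shown alone.

Measured so far in the series:
compound 1, `C=CS(=O)(=O)N1CCN(c2ncnc3sc(-c4ccc(C#N)cc4)cc23)CC1` — 8050 nM
compound 2, `C=CS(=O)(=O)N1CCN(c2nc(OCC3CCCCN3C)nc3sc(-c4ccc(C#N)cc4)cc23)CC1` — 3180 nM
compound 3, `CCS(=O)(=O)N1CCN(c2ncnc3sc(-c4ccc(N5CCN(C)CC5)cc4)cc23)CC1` — 7330 nM

In a functional assay on MDA-MB-231 cells (Homo sapiens) for antiproliferative activity, read by MTT assay, with a stated time of 48 h (a lower number here means a stronger inhibitor, a higher number a weaker inhibitor), compound 3 gives 7330 nM, the second highest of the three numbers. It sits alongside compound 1, that gap within the scatter, and clearly higher than compound 2, that gap beyond the scatter. Among the compounds with values here, the only single-point step measured is a 2.5-fold lower number from compound 1 to compound 2 (0.40 log units; beyond the scatter), a change on an aromatic carbon of the shared core and not at the ring nitrogen altered here.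

Compound 4, `CN1CCN(c2ccc(-c3cc4c(N5CCN(C(=O)Nc6ccccc6F)CC5)ncnc4s3)cc2)CC1`, differs from compound 3 by (2-fluorophenyl)carbamoyl in place of ethylsulfonyl on an amine nitrogen in a ring. Within the data shown here, no measured step touches this site, so the series gives no direction for the change; what is expected is a step no larger than the scatter, a 1.5-fold lower number from compound 3 to compound 4 (0.17 log units; within the scatter), with wide uncertainty on either side. Compound 4 is therefore estimated at 5000 nM in this assay, with a range from 1500 nM to 18000 nM.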

Compound 4, half-maximal inhibitory concentration: 10300 nM
The estimate for compound 4 lay 2.1-fold (0.31 log units) below the measured number, and the stated range covers the measured number.
By their numbers in this assay, from the lowest: compound 2; then compounds 3, 1 and 4 (each within the scatter of the next).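

In this assay, within the data shown here, this is the first measured step at the amine nitrogen of the six-membered non-aromatic ring with 2 nitrogen: (2-fluorophenyl)carbamoyl in place of ethylsulfonyl gives a 1.4-fold higher number from compound 3 to compound 4 (0.15 log units; within the scatter). At this site, then, an exchange from 5 heavy atoms without a ring to 10 heavy atoms with a six-membered aromatic ring leaves the two numbers within the scatter of each other. No measurement shown here accounts for the size of this step.

Open, as far as these compounds go, is whether an acetyl group or a bare hydrogen on this nitrogen, or a carboxylic acid on the phenyl ring of the carbamoyl group, would move the number beyond the scatter. Also open, from the compounds shown here alone, is whether (1-methylpiperidin-2-yl)methoxy on the aromatic carbon of the shared core would give a similar step with (2-fluorophenyl)carbamoyl on this nitrogen.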